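The source may hold more compounds than are shown below. What is called first, only, known or untested is meant among the compounds shown, and "the series" means these compounds.

Urea series on the shared core of compound 1, `O=C(Nc1cnc(-n2nccn2)c(Cl)c1)Nc1cnc2ccccc2c1C1CC1`. In a functional assay on OCI-Ly3 cells (Homo sapiens) for antiproliferative activity (a higher number here means that more compound is needed for the effect, a lower number that less compound is needed), compound 1 gives 1580 nM. Compound 2, `O=C(Nc1cnc(-n2nccn2)c(Cl)c1)Nc1cnc2cc(F)ccc2c1C1CC1`, carries fluoro in place of hydrogen on an aromatic carbon; in this assay compound 2 gives 900 nM, a step of a 1.8-fold lower number from compound 1 to compound 2 (0.24 log units; within the scatter). Compound 3, `COC(C)c1c(NC(=O)Nc2cnc(-n3nccn3)c(Cl)c2)cnc2ccccc12`, differs from compound 1 by 1-methoxyethyl in place of cyclopropyl on an aromatic carbon, and in this assay compound 3 gives 620 nM, a step of a 2.5-fold lower number from compound 1 to compound 3 (0.41 log units; beyond the scatter). The numbers of compound 2 and compound 3 lie within the scatter of each other, so no order between them is read.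

Compound 4, `COC(C)c1c(NC(=O)Nc2cnc(-n3nccn3)c(Cl)c2)cnc2ccc(F)cc12`, is not yet measured in this assay. It differs from compound 3 by fluoro in place of hydrogen on an aromatic carbon, the same change as the one made on the core of compound 1, now applied to the core of compound 3. Because the earlier change gave a 1.8-fold lower number from compound 1 to compound 2 (0.24 log units; within the scatter), a step of a 1.5-fold lower number from compound 3 to compound 4 (0.17 log units; within the scatter) is expected here, of similar size and likewise within the scatter. For compound 4 in this assay the expected number is 420 nM, estimated to fall between 200 nM and 900 nM.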

Compound 4, half-maximal effective concentration: 270 nM
Estimate against measurement, compound 4: 1.6-fold (0.19 log units) above; the range from low to high includes it.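

In this assay fluoro in place of hydrogen gives a 2.3-fold lower number from compound 3 to compound 4 (0.36 log units; beyond the scatter) and so lines up with the earlier step on the core of compound 1: the same change on two cores in this assay, a 1.8-fold lower number (0.24 log units; within the scatter) from compound 1 to compound 2 and a 2.3-fold lower number (0.36 log units; beyond the scatter) from compound 3 to compound 4, 1.3-fold (0.12 log units) apart, within the scatter of two such steps. Among the compounds shown here, the change therefore carries over between these two cores, with steps that cannot be told apart in size, even though only the step on the core of compound 3 lies beyond the scatter. This rests on one pair of steps in a single cell assay, so it does not show that fluoro would give a similar step on other cores in the series, and it gives no reason for the step.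

Still open, from the compounds shown here alone, is whether the step holds when the 1-methoxyethyl group gives way to a longer ether chain or an amine. Also open, going by these compounds, is whether chloro or methoxy in place of the fluoro, or fluoro on another aromatic carbon of the same ring, would give a step of similar size.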